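Swapping the Ring on the Amine Side Chain of Compound 1

The compounds below may be only part of what the source reports. "The series", "measured", "known", "first", "only" and "open" are said of these compounds alone.

Compound 1, `CCC(C(=O)N[C@@H](CC(=O)O)C(=O)CSCc1ccccc1)n1ccnc(NCC2COc3ccccc3O2)c1=O`: 30 nM
Compound 2, `CCC(C(=O)N[C@@H](CC(=O)O)C(=O)CNCN1CCCCC1)n1cc(C(C)(C)C)nc(NCc2nonc2C)c1=O`: 0.29 nM
Compound 3, `CCC(C(=O)N[C@@H](CC(=O)O)C(C)=O)n1cc(C(C)(C)C)nc(NCc2nonc2C)c1=O`: 5.12 nM

In a functional assay on NT2 cells (Homo sapiens) for inhibition (on this read-out higher numbers stand for weaker inhibition and lower numbers for stronger inhibition), compound 1 gives the highest number of the three, with compound 3 nearest and compound 2 furthest below it. Compound 4, `CCC(C(=O)N[C@@H](CC(=O)O)C(=O)CSCc1ccccc1)n1ccnc(NCc2cc(C)no2)c1=O`, keeps the core and the thioether side chain of compound 1 but carries 3-methyl-1,2-oxazol-5-yl in place of 2,3-dihydro-1,4-benzodioxin-2-yl on a saturated chain carbon bound to a nitrogen on an aromatic ring. Among the measured compounds shown here, no measured pair shows this change; the one single-point step, an 18-fold higher number from compound 2 to compound 3 (1.25 log units; beyond the scatter), concerns a different position and on compounds that also carry a tert-butyl group and another ring. With no comparison to lean on, the expected step is no change at the digits printed from compound 1 to compound 4 (within the scatter), none beyond the scatter. Compound 4 is therefore estimated at 30 nM, within 8 nM to 110 nM.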

Compound 4, half-maximal inhibitory concentration: 6.41 nM
Compound 4: the middle estimate sits 4.7-fold (0.67 log units) above what was measured; measured number outside the range, below it.
By their numbers in this assay, from the lowest: compound 2; then compounds 3 and 4 (each within the scatter of the next); then compound 1.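

In this assay, this position on the amine side chain responds to a change of ring: 3-methyl-1,2-oxazol-5-yl in place of 2,3-dihydro-1,4-benzodioxin-2-yl gives a 4.7-fold lower number from compound 1 to compound 4 (0.67 log units; beyond the scatter) with the rest of compound 1 untouched. The entering group is the smaller one, with fewer heavy atoms than the group it replaces, and its ring is aromatic throughout. Nothing measured here explains the step.

Ring size and aromatic character change together in this swap, so their separate contributions stay open. A cyclopropyl group or a pyridine ring on the same carbon would help pull them apart.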